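Swapping fluoro for methyl on the carbamate aryl ring

The source may report more compounds than this note shows. Statements on the series, on what has been measured and on what is new or still open speak of the compounds shown alone.

Measured compounds:
compound 1, `O=C(Nc1cccc(Cl)c1)O/N=C(\C1CCCCC1)C(Cn1ccnc1)C1CCCCC1`, 117 nM; 76 nM (2 entries)
compound 2, `O=C(Nc1cccc(F)c1)O/N=C(\C1CCCCC1)C(Cc1cccs1)C1CCCCC1`, 46 nM

Both compounds share a core built around an oxime carbamate carrying two cyclohexyl groups; they differ in the side chain and in the substituent on the aromatic ring of the carbamate. In a functional assay on E17 cells for antagonist activity at metabotropic glutamate receptor 5 (Rattus norvegicus), read by fluorescence and calcium flux (a lower number here means a stronger inhibitor, a higher number a weaker inhibitor), compound 1 gives 117 nM; 76 nM (2 entries), and the spread of its repeats is seen in the several entries of compound 1 in this assay, 117 nM; 76 nM (2 entries). In this assay compound 2 gives 46 nM. Compound 2 therefore stands close to compound 1; one further record for compound 2 exists that yields no single number.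

Compound 3, `Cc1cccc(NC(=O)O/N=C(\C2CCCCC2)C(Cc2cccs2)C2CCCCC2)c1`, has not been measured. Its difference from compound 2 is methyl in place of fluoro on an aromatic carbon, meta to a large group. Going by the values given here, no pair of measured compounds isolates this change, so nothing tells how much it should matter. With one small substituent replaced by another at the same place, the expectation is a step no larger than the scatter, in no firm direction. Compound 3 is expected to give about 55 nM, between 20 nM and 150 nM, which means an estimated step of a 1.2-fold higher number from compound 2 to compound 3 (0.08 log units; within the scatter).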

Compound 3, half-maximal inhibitory concentration: 48 nM
Compound 3: middle estimate off by 1.1-fold (0.06 log units), on the high side; low and high end bracket the measured number.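

Going by these compounds alone, this is the first pair that differs in only one place, so it isolates the change from 3-fluorophenyl to 3-methylphenyl on the carbamate: in this assay, the step is a 1.0-fold higher number from compound 2 to compound 3 (0.02 log units; within the scatter). At this place on the ring, meta to a large group, fluoro and methyl, each a single heavy atom, therefore cannot be told apart by this read-out, and compound 3 stays in the same range as compound 2. The step is also much smaller than the gap between two repeat measurements of a single compound, so it offers no basis for ranking the two groups: the several entries of compound 1 in this assay, 117 nM; 76 nM (2 entries)

What the compounds shown leave open is how far this tolerance extends, since a pair of small groups says little about an amine, a carboxylic acid or a longer chain such as propyl at the same place. Within the data shown here, it is also unknown whether the swap from fluoro to methyl would read the same on a compound with a different side chain, such as the one in compound 1.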